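The source may hold more compounds than are shown below. What is called first, only, known or untested is meant among the compounds shown, and "the series" means these compounds.

Measured compounds:
compound 1 `Clc1ccc(Cl)c(COC(CCn2ccnc2)c2cccs2)c1` — an ADME assay on J774.A1 cells (Mus musculus) for cytotoxicity, read by MTT assay, with a stated time of 72 h; a higher number here means that more compound is tolerated, a lower number that less compound is tolerated: 18000 nM
compound 2 `Clc1ccc(Cl)c(COC(CCn2cncn2)c2cccs2)c1` — this assay: "not determined" (no result reported)

Among the compounds with values here, compound 1 is the only compound of the set that carries a number in this assay; compound 2 has no result there, so nothing can be said of how the two stand to each other. Compound 3 `Clc1ccc(Cl)c(COC(CCn2ccnc2)c2ccco2)c1` has not yet been tested in this assay. It differs from compound 1 in a single place: furan-2-yl in place of thiophen-2-yl on a saturated chain carbon bound to an oxygen on a saturated carbon and a saturated chain carbon. Within the data shown here, no pair of measured compounds differs in one place, so there is no measured step that could guide the expectation; the only anchor is the value of compound 1. Because compound 1 gives 18000 nM in this assay, and the change exchanges one five-membered aromatic ring with one hetero atom for another of the same count, the expected step is small, no change at the digits printed from compound 1 to compound 3 (within the scatter), in no particular direction and not beyond the usual scatter of repeated measurements. Compound 3 is therefore estimated at 18000 nM in this assay, with a range from 8000 nM to 40000 nM.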

Compound 3, half-maximal cytotoxic concentration: 37600 nM
For compound 3 the middle estimate is 2.1-fold (0.32 log units) below the measured one, within the range that was stated.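

Within the data shown here, this is the first measured step in the set: in this assay the exchange of thiophen-2-yl for furan-2-yl on a saturated chain carbon bound to an oxygen on a saturated carbon and a saturated chain carbon gives a 2.1-fold higher number from compound 1 to compound 3 (0.32 log units; beyond the scatter) as a modest change. It shows that this position is not silent in this assay even for a close exchange, since both groups are five-membered aromatic rings with 1 hetero atom, have 5 heavy atoms, and carry the same counts of donors and acceptors and no net charge, with sulfur giving way to oxygen as the difference in atoms. Nothing available explains why the number moves in this direction.

On these data alone, with a single step at a single position, it remains open whether a phenyl ring or an amine at this place would shift the number further, or in the opposite direction. As far as these compounds go, compound 2 carries no number, so the change that separates it from compound 1 cannot be read, and whether the step seen here would hold on another part of the core also stays open.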